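Ethyl-to-propyl carbamate homologation on a pyrazoline series

The compounds below may be only part of what the source reports. "The series", "measured", "known", "first", "only" and "open" are said of these compounds alone.

Measured compounds, in a functional assay on HepG2 cells (Homo sapiens) for antiproliferative activity, read by MTT assay, with a stated time of 48 h; on this read-out lower numbers stand for stronger inhibition of growth and higher numbers for weaker inhibition of growth:
compound 1, `COC(=O)N1N=C(c2ccc(OC)cc2)CC1c1cc(OC)c(OC)c(OC)c1`, gives 1710 nM
compound 2, `CCOC(=O)N1N=C(c2ccc(OC)cc2)CC1c1cc(OC)c(OC)c(OC)c1`, gives 9400 nM
compound 3, `CCOC(=O)N1N=C(c2cccc(O)c2)CC1c1cc(OC)c(OC)c(OC)c1`, gives 1790 nM

The one-step change from compound 1 to compound 2, (methyl in place of hydrogen on a saturated chain carbon bound to an oxygen next to a carbonyl group), gave a 5.5-fold higher number from compound 1 to compound 2 (0.74 log units; beyond the scatter). Compound 3 shares the ethyl carbamate of compound 2; the difference between the core of compound 3 and that of compound 1 is not broken down here. The change a 5.3-fold lower number from compound 2 to compound 3 (0.72 log units; beyond the scatter) brought the number back to the level of compound 1, the two being within the scatter.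

Compound 4, `CCCOC(=O)N1N=C(c2cccc(O)c2)CC1c1cc(OC)c(OC)c(OC)c1`, is still to be measured. It differs from compound 3 by methyl in place of hydrogen on a saturated chain carbon, two bonds along the chain from an oxygen next to a carbonyl group. This is the same kind of change as that from compound 1 to compound 2, but the place is not the same: there the methyl entered on a saturated chain carbon bound to an oxygen next to a carbonyl group, here on a saturated chain carbon, two bonds along the chain from an oxygen next to a carbonyl group. For the measured compounds named here, the only comparable step, a 5.5-fold higher number from compound 1 to compound 2 (0.74 log units; beyond the scatter), weakened growth inhibition; a step in the same direction but smaller is expected, a 2.5-fold higher number from compound 3 to compound 4 (0.40 log units; beyond the scatter), since it rests on a single pair. Compound 4 is thus estimated at 4500 nM, with a range from 1800 nM to 12000 nM.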

Compound 4, concentration for 50% growth inhibition: > 10000 nM
Compound 4 ended at the assay's limit; the forecaster's own chance of this, stated with the estimate: 10%; middle value at least 2.2-fold (0.34 log units) from the limit.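

In this assay, compound 4 gives > 10000 nM, which is a limit of the assay and not a number. The step reads an at least 5.5-fold higher number from compound 3 to compound 4 (0.74 log units; beyond the scatter), so on the core of compound 3, growth inhibition also weakened when the ethyl carbamate was extended to the propyl carbamate, in the same direction as the step from methyl to ethyl carbamate on the core of compound 1. The direction therefore carries over between these two cores, though each rests on a single pair and the sizes cannot be compared: the same change on two cores in this assay, a 5.5-fold higher number (0.74 log units; beyond the scatter) from compound 1 to compound 2 and an at least 5.5-fold higher number (0.74 log units; beyond the scatter) from compound 3 to compound 4; the limit leaves it open whether they differ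

The series leaves open how a methyl carbamate behaves on the core of compound 3 and how a propyl carbamate behaves on the core of compound 1, so each chain length is seen on one core only. Also open, on these data alone, is whether a longer chain such as butyl, a branched chain such as isopropyl, or an amine at the end of the chain would follow the same direction.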